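Ester to Amide at the End of a Chain

A few compounds are considered here, and "the series" means these few. Any claim that something is new, unique, unknown or untested is made for them only; others in the source may bear on it.

Compound 2 `C=CCc1cc(C(C)=O)c(O)cc1OCCCCCC(=O)OC` stands highest of the two compounds measured: in an assay on isolated protein for binding affinity to leukotriene B4 receptor 1 (Homo sapiens), tested at 1 uM (on this read-out lower numbers stand for less inhibition and higher numbers for more inhibition at the one concentration tested (going by the name of the read-out)), compound 2 gives 65%, while compound 1 `C=CCc1cc(C(C)=O)c(O)cc1OCCCCO` gives 9%. Among the measured compounds shown here, the single measured step, a number 56 percentage points higher from compound 1 to compound 2 (beyond the scatter), replaced hydroxy on the chain with a larger group; it concerns a different position and only loosely informs the next step. Compound 3 `C=CCc1cc(C(C)=O)c(O)cc1OCCCCCC(=O)N(C)C` carries the change (dimethylamino in place of methoxy on a carbonyl carbon). For the measured compounds named here, with no direct precedent, a small step is expected in this assay, a number 8 percentage points lower from compound 2 to compound 3 (within the scatter), likely within the scatter. Compound 3 is estimated at 57%, ranging from 32% to 80%.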

Compound 3, a percentage reported as inhibition, at one concentration (the size of the read-out at that concentration, not a potency): 54%
Beside the measured number, compound 3's estimate is 3 percentage points above it; the range from low to high includes it.
By their numbers in this assay, from the lowest: compound 1; then compound 3; then compound 2.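

In this assay, the carbonyl end of the chain responds to this change: dimethylamino in place of methoxy gives a number 11 percentage points lower from compound 2 to compound 3 (beyond the scatter) on the carbonyl carbon. With a number 45 percentage points higher from compound 1 to compound 3 (beyond the scatter) in place of the hydroxy chain end, the amide still holds most of the rise seen with the ester, so a high number here does not depend on the ester alone. Nothing measured here explains the difference between these groups. Still open, on these data alone, is how a carboxylic acid or a primary amide would read at this chain end, and what a longer chain would do.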